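The source may report more compounds than this note shows. Statements on the series, on what has been measured and on what is new or still open speak of the compounds shown alone.

Measured compounds in a functional assay on HCT-116 cells (Homo sapiens) for inhibition, read by MTT assay, with a stated time of 72 h; on this read-out higher numbers stand for weaker inhibition and lower numbers for stronger inhibition:
Compound 1 `CCN1CCN(Cc2c(OC)cc(Oc3cccc(Nc4ccccc4)c3)cc2OC)CC1` gives > 20000 nM in this assay, a limit of the assay rather than a number.
Compound 2 `COc1cc(Oc2cccc(Nc3ccccc3)c2)cc(OC)c1CNCc1ccc(Br)cc1` gives 6230 nM in this assay.
Compound 3 `COc1ccc(CNCc2c(OC)cc(Oc3cccc(Nc4ccccc4)c3)cc2OC)cc1` gives 2620 nM in this assay.

Compound 2 holds the highest of the two numbers shown; its nearest neighbour is compound 3, reached by a 2.4-fold lower number from compound 2 to compound 3 (0.38 log units; beyond the scatter). Compound 4 `COc1cc(Oc2cccc(Nc3ccccc3)c2)cc(OC)c1CNCc1ccc(F)cc1` differs from compound 2 by fluoro in place of bromo on an aromatic carbon. Going by the values given here, the only measured step at that position is a 2.4-fold lower number from compound 2 to compound 3 (0.38 log units; beyond the scatter), where methoxy enters rather than fluoro; an at least 3.2-fold lower number from compound 1 to compound 2 (0.50 log units; beyond the scatter) concerns the other end of the molecule. Among the compounds with values here, no fluoro analogue has been measured, so a modest move in either direction or none beyond the scatter is possible. Compound 4 is expected to change by a 1.0-fold lower number from compound 2 to compound 4 (0.02 log units; within the scatter). Compound 4 is estimated at 6000 nM, between 2500 nM and 15000 nM.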

Compound 4, half-maximal inhibitory concentration: 4220 nM
Estimate against measurement, compound 4: 1.4-fold (0.15 log units) above; measured number inside the range.
By their numbers in this assay, from the lowest: compounds 3, 4 and 2 (each within the scatter of the next, the first and the last beyond it). At a limit, above all of these: compound 1.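

In this assay, fluoro in place of bromo gives a 1.5-fold lower number from compound 2 to compound 4 (0.17 log units; within the scatter), and fluoro in place of methoxy gives a 1.6-fold higher number from compound 3 to compound 4 (0.21 log units; within the scatter), so compound 4 lies within the scatter of both compound 2 and compound 3, although those two lie beyond the scatter of each other. The (4-fluorobenzyl)amino group in place of 4-ethylpiperazin-1-yl gives an at least 4.7-fold lower number from compound 1 to compound 4 (0.67 log units; beyond the scatter). That step rests on the value of compound 1, which is a limit: the limit of > 20000 nM in this assay, at which 1 of the 4 values shown sits.

Still open, as far as these compounds go, is how a hydroxyl, a carboxylic acid or a plain hydrogen at this aromatic carbon would read. Also open, from the compounds shown here alone, is whether a longer chain between the amine and the aromatic ring would shift the number.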